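EP4 antagonist benzamide series: fluoro-to-methyl step on the core

This account rests on a few compounds, and the source may have more. Where it says the series, first, only, none or still open, it means among the compounds named here.

Measured so far:
- Compound 1, `Cc1cc(C(=O)O)cc(C)c1NC(=O)c1nc(-c2cccc(CO)c2)ccc1C(F)(F)F`: 0.67 nM
- Compound 2, `Cc1ccc(C(=O)O)c(C)c1NC(=O)c1nc(-c2cccc(CO)c2)ccc1C(F)(F)F`: 1.94 nM
- Compound 3, `Cc1ccc(C(=O)O)c(C)c1NC(=O)c1cc(-c2cccc(CO)c2)ccc1F`: 4.49 nM

All three numbers come from a functional assay on HEK293 cells for antagonist activity at prostaglandin E2 receptor EP4 subtype (Homo sapiens), read by HTRF and cAMP accumulation, with a stated time of 1 h; a lower number here means a stronger inhibitor, a higher number a weaker inhibitor. Compound 3 gives the highest number of the three; compound 2 sits nearest, and the gap between compound 3 and compound 2 lies beyond the scatter, as does the larger gap between compound 3 and compound 1. Compound 3 is thus the weakest inhibitor among the measured compounds.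

Compound 4, `Cc1ccc(-c2cccc(CO)c2)cc1C(=O)Nc1c(C)ccc(C(=O)O)c1C`, is not yet measured. It differs from compound 3 in one place: methyl in place of fluoro on an aromatic carbon, the position being ortho to a large group and para to the 3-(hydroxymethyl)phenyl group on the core. Going by the values given here, no measured pair shows this change, so its size cannot be read from the existing numbers. The expectation in this assay is a small step, if any, in either direction, most likely not far beyond the scatter; the estimate leans toward a slightly higher number. Compound 4 is expected to give 6.5 nM, within 2 nM to 20 nM, an expected step of a 1.4-fold higher number from compound 3 to compound 4 (0.16 log units; within the scatter).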

Compound 4, half-maximal inhibitory concentration in the prostaglandin E2 receptor EP4 subtype assay: 2.31 nM
For compound 4 the middle estimate is 2.8-fold (0.45 log units) above the measured one; the measured number falls inside the stated range.
By their numbers in the prostaglandin E2 receptor EP4 subtype assay, from the lowest: compound 1; then compounds 2, 4 and 3 (each within the scatter of the next, the first and the last beyond it).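

Going by these compounds alone, in the prostaglandin E2 receptor EP4 subtype assay compound 3 gives 4.49 nM and compound 4 gives 2.31 nM and so methyl in place of fluoro on this aromatic carbon, ortho to a large group and para to the 3-(hydroxymethyl)phenyl group, gives a 1.9-fold lower number from compound 3 to compound 4 (0.29 log units; within the scatter) and stays within the scatter, the first reading of this change. In a physicochemical assay for solubility, read by HPLC, with a stated time of 20 h, at pH 6 (on this read-out lower numbers stand for lower solubility and higher numbers for higher solubility), compound 3 gives 709 ug/mL and compound 4 gives 783 ug/mL and so the same change gives a 1.1-fold higher number from compound 3 to compound 4 (0.04 log units; within the scatter) and also stays within the scatter. On this one pair, then, fluoro and methyl at this position are not told apart by either read-out, and nothing on hand offers an explanation.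

Still open, going by these compounds, is whether another group at this position, such as a methoxy, a nitrile or an amine, would move either read-out beyond the scatter. Also open, on these data alone, is whether the same change would read alike on the core of compound 2, with its trifluoromethyl group.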